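A few compounds are considered here, and "the series" means these few. Any claim that something is new, unique, unknown or untested is made for them only; others in the source may bear on it.

Measured so far:
compound 1 `O=C(COc1ccc2cc(/C=C3/SC(=O)NC3=O)ccc2c1)Nc1cccc(Cl)c1`: 10600 nM
compound 2 `O=C(COc1ccc2cc(/C=C3/SC(=O)NC3=O)ccc2c1)Nc1c(F)cc(F)cc1Br`: 9600 nM

In a functional assay on CCRF-CEM cells (Homo sapiens) for cytotoxicity, with a stated time of 20 h (on this read-out lower numbers stand for higher toxicity in this test and higher numbers for lower toxicity in this test), compound 1 gives 10600 nM, and compound 2 gives 9600 nM. Going by the values given here, the one measured step, a 1.1-fold lower number from compound 1 to compound 2 (0.04 log units; within the scatter), exchanged the aryl group on the amide-type nitrogen and left the read-out unchanged beyond the scatter. Compound 2 holds the lower of the two numbers, but the gap to compound 1 is within the scatter, so no order between them can be read.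

Compound 3 `O=C(COc1ccc2cc(/C=C3/SC(=O)NC3=O)ccc2c1)Nc1ccc(Br)cc1F` has not yet been measured in this assay. Its change from compound 2: 4-bromo-2-fluorophenyl in place of 2-bromo-4,6-difluorophenyl on an amide-type nitrogen. Among the compounds with values here, the only step bearing on it is a 1.1-fold lower number from compound 1 to compound 2 (0.04 log units; within the scatter), a change of the same kind at the same place, which stayed within the scatter. Nothing in these two measurements points to a shift in either direction, so no step beyond the scatter is expected. Compound 3 is estimated at 10000 nM, with a range from 5000 nM to 20000 nM. The expected step is a 1.0-fold higher number from compound 2 to compound 3 (0.02 log units; within the scatter).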

Compound 3, half-maximal cytotoxic concentration: 40900 nM
Beside the measured number, compound 3's estimate is 4.1-fold (0.61 log units) below it; the measured number lies above the stated range.
By their numbers in this assay, from the lowest: compounds 2 and 1 (each within the scatter of the next); then compound 3.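

In this assay the aryl group on the amide-type nitrogen does matter: the change reads as a 4.3-fold higher number from compound 2 to compound 3 (0.63 log units; beyond the scatter) and as a 3.9-fold higher number from compound 1 to compound 3 (0.59 log units; beyond the scatter) when 4-bromo-2-fluorophenyl is the group entering. So 4-bromo-2-fluorophenyl stands apart from both 2-bromo-4,6-difluorophenyl and 3-chlorophenyl, two groups whose compounds remain within the scatter of each other, and compound 3 is the least toxic of the three in this test. No measurement at hand speaks to what lies behind these steps.

Going by these compounds alone, still open is whether the higher number follows the 4-bromo-2-fluorophenyl group as a whole or only one of its two halogens, as no compound here separates them. Also open, as far as these compounds go, is how an aryl group carrying an amine or a carboxylic acid, or a longer alkyl chain on the amide-type nitrogen, would read in this assay on the same core.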